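The source may report more compounds than this note shows. Statements on the series, on what has been measured and on what is new or still open speak of the compounds shown alone.

For the measured compounds named here, only two compounds have so far been tested in a functional assay on B16 cells (Mus musculus) for inhibition, with a stated time of 72 h; on this read-out lower numbers stand for stronger inhibition and higher numbers for weaker inhibition. There, compound 1 `Cc1ccc(CN2CCCNC2=S)cc1` gives 5100 nM. Compound 2 `COc1ccc(CN2CCCNC2=O)cc1` yields no number, only a limit of the assay, > 10000 nM. This places compound 2 at the limit of > 10000 nM in this assay, at which 1 of the 2 values shown sits.

Compound 3 `CC(C)c1ccc(CN2CCCNC2=O)cc1` keeps the core of compound 2 and changes one group: isopropyl in place of methoxy on an aromatic carbon. Isopropyl stands in place of methoxy on an aromatic carbon, para to a group of 8 heavy atoms. Going by the values given here, no measured pair shows what such a change does in this assay, so no step beyond the scatter is expected, in either direction. The estimated change, a number no higher from compound 2 to compound 3 (the limit leaves the size open), is therefore small, and another limit is the likelier report. For compound 3 the expected value is 10000 nM, with an estimated range from 3000 nM to 30000 nM.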

Compound 3, half-maximal inhibitory concentration: > 10000 nM
Compound 3: only a limit was reported (the forecaster's own chance of this, stated with the estimate: 60%); the middle value lies on the limit itself.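

Compound 2 and compound 3 are both reported only as limits of the assay, so no step can be read between them: the limit of > 10000 nM in this assay, at which 2 of the 3 values shown sit. The compounds shown leave open whether isopropyl in place of methoxy on an aromatic carbon changes inhibition at all, and by how much.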